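A few compounds are considered here, and "the series" means these few. Any claim that something is new, unique, unknown or untested is made for them only; others in the source may bear on it.

Measured so far:
- compound 1 `Cc1ccc(NC(=S)NC(=O)c2ccc(OCc3ccc(F)cc3)cc2)cc1-c1nc2ccccc2[nH]1`: 4220 nM
- compound 2 `Cc1ccc(NC(=O)NC(=O)c2ccc(OCc3cccc(Cl)c3)cc2)cc1-c1nc2ccccc2[nH]1`: 28000 nM

In a functional assay on MNK45 cells (Homo sapiens) for inhibition, read by MTT assay, with a stated time of 48 h (on this read-out lower numbers stand for stronger inhibition and higher numbers for weaker inhibition), compound 1 gives 4220 nM, and in this assay compound 2 gives 28000 nM, the higher of the two numbers, with a gap between them that lies beyond the scatter. Compound 3 `Cc1ccc(NC(=O)NC(=O)c2ccc(OCc3cccc(C(F)(F)F)c3)cc2)cc1-c1nc2ccccc2[nH]1` has not been measured. It differs from compound 2 by trifluoromethyl in place of chloro on an aromatic carbon. Going by the values given here, no measured pair shows this kind of change, so the step is expected to be small, with no clear direction beyond the scatter. For compound 3 the estimated value in this assay is 25000 nM, ranging from 8000 nM to 70000 nM, a step of a 1.1-fold lower number from compound 2 to compound 3 (0.05 log units; within the scatter).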

Compound 3, half-maximal inhibitory concentration: 9600 nM
Compound 3: the middle estimate sits 2.6-fold (0.42 log units) above what was measured, within the range that was stated.
By their numbers in this assay, from the lowest: compound 1; then compound 3; then compound 2.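

Going from 3-chlorobenzyl to 3-(trifluoromethyl)benzyl gives, in this assay, a 2.9-fold lower number from compound 2 to compound 3 (0.46 log units; beyond the scatter). Going by these compounds alone, this is the first change confined to one place, and it shows that the read-out responds to the group held at this position. No available evidence accounts for the step. 

As far as these compounds go, a single pair gives no trend, so how an amine or a carboxylic acid at this position would read remains open. Also open, from the compounds shown here alone, is whether the same exchange holds with the thiocarbonyl of compound 1, which differs from compound 2 in more than one place.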